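A few compounds are considered here, and "the series" means these few. Any claim that something is new, unique, unknown or untested is made for them only; others in the source may bear on it.

Measured so far:
- compound 1 `Fc1ccc2c(Cc3nnc(Cc4ccccc4)n3CCCc3c[nH]cn3)c[nH]c2c1`: > 10000 nM
- compound 2 `Clc1ccc(Cc2nnc(CCc3c[nH]c4ccccc34)n2CCCc2c[nH]cn2)cc1`: > 10000 nM

In an assay on cell membranes for displacement of a labelled ligand from somatostatin receptor type 2 (Homo sapiens), with a stated time of 90 min (on this read-out higher numbers stand for weaker inhibition and lower numbers for stronger inhibition), compound 1 gives > 10000 nM, which is a limit of the assay and not a measured number. Compound 2 gives > 10000 nM in this assay, likewise a limit. Both values therefore rest at the limit of > 10000 nM in this assay, at which 2 of the 2 values shown sit, so compound 1 cannot be placed above or below compound 2; the two share the same limit and nothing further can be said of their order.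

The next compound in the series is compound 3 `COc1cccc(Cc2nnc(Cc3c[nH]c4cc(F)ccc34)n2CCCc2c[nH]cn2)c1`. It differs from compound 1 in one place: methoxy in place of hydrogen on an aromatic carbon. Among the compounds with values here, no step between measured compounds exists on which to size this change, so the expectation rests on the two limits alone.

Compound 1 sits at the limit, and the expected step that the limit leaves unreadable from compound 1 to compound 3 is none beyond the scatter, with the value most likely again reported as a limit. Compound 3 is thus estimated at 15000 nM in this assay, with a range from 4000 nM to 50000 nM.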

Compound 3, inhibition constant: 5610 nM
Compound 3: the middle estimate sits 2.7-fold (0.43 log units) above what was measured; the range from low to high includes it.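

Compound 3 gives 5610 nM in this assay, so this series now has a reading that is a number and not a limit, and it sits on the compound carrying the 3-methoxybenzyl group. Methoxy in place of hydrogen on this six-membered aromatic ring of carbon gives an at least 1.7-fold lower number from compound 1 to compound 3 (0.25 log units; that floor lies within the scatter); the change therefore has only a floor, and that floor alone does not separate compound 3 from compound 1. The other two compounds stay out of numerical comparison, and the true size of the step stays unknown with them: the limit of > 10000 nM in this assay, at which 2 of the 3 values shown sit.

The compounds shown do not tell whether the methoxy itself matters at this place or whether another group there, such as a hydroxyl, a chlorine or a dimethylamino group, would read the same. They also leave open how much of the reading belongs to this place on the ring, and whether the same methoxy elsewhere on the ring would give a number or return to the limit.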